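Aryl group change on the ring amine nitrogen

This account rests on a few compounds, and the source may have more. Where it says the series, first, only, none or still open, it means among the compounds named here.

Measured compounds in an assay on HEK293 cells for displacement of a labelled ligand from 5-hydroxytryptamine receptor 7 (Homo sapiens); a lower number here means a stronger inhibitor, a higher number a weaker inhibitor:
- compound 1 `O=C1c2ccccc2S(=O)(=O)N1CCCCCN1CCN(c2ccc(Cl)cc2)CC1`: 191 nM
- compound 2 `O=C1c2ccccc2S(=O)(=O)N1CCCCCCN1CCN(c2cccc(Cl)c2Cl)CC1`: 487 nM
- compound 3 `O=C1c2ccccc2S(=O)(=O)N1CCCCCN1CCN(c2ccccn2)CC1`: 179 nM

Compound 3 gives the lowest number of the three in this assay, but the step of a 1.1-fold lower number from compound 1 to compound 3 (0.03 log units; within the scatter) shows that it cannot be told apart from compound 1. For the measured compounds named here, compound 2, which carries a longer chain and a different aryl group and for which no single-change step exists, gives a number clearly higher than compound 3.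

The next compound, compound 4 `O=C1c2ccccc2S(=O)(=O)N1CCCCCN1CCN(c2cccc(C(F)(F)F)c2)CC1`, differs from compound 3 in one place: 3-(trifluoromethyl)phenyl in place of pyridin-2-yl on an amine nitrogen in a ring. Going by the values given here, no measured step covers this exact exchange. Among the compounds with values here, the only bearing step is the aryl swap from compound 1 to compound 3, which was within the scatter, so one exchange of a six-membered aromatic group on this ring nitrogen has left the number essentially unchanged. Within the data shown here, the only aryl group that gave a clearly higher number, that of compound 2, came together with a chain change, so nothing separates the two effects.

On this basis a step of a 1.2-fold higher number from compound 3 to compound 4 (0.07 log units; within the scatter) is expected, lying within the scatter. Compound 4 is therefore estimated at 210 nM, with a range from 80 nM to 550 nM.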

Compound 4, inhibition constant: 35 nM
The estimate for compound 4 lay 6.0-fold (0.78 log units) above the measured number; measured number below the stated range.
By their numbers in this assay, from the lowest: compound 4; then compounds 3 and 1 (each within the scatter of the next); then compound 2.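

In this assay, the aryl group on the amine nitrogen in the ring clearly affects the number: a 5.1-fold lower number from compound 3 to compound 4 (0.71 log units; beyond the scatter), and a 5.5-fold lower number from compound 1 to compound 4 (0.74 log units; beyond the scatter), both beyond the scatter. The earlier exchange, a 1.1-fold lower number from compound 1 to compound 3 (0.03 log units; within the scatter), therefore does not show that this position is indifferent to its six-membered aromatic group, since 3-(trifluoromethyl)phenyl separates itself from both 4-chlorophenyl and pyridin-2-yl while the chain and the shared core stay the same. The data in hand offer no measurement that explains this separation.

Going by these compounds, it remains open whether the lower number depends on the trifluoromethyl group itself or would also appear with a nitrile or a methoxy group in its place on the phenyl ring. On these data alone, it is also open whether 3-(trifluoromethyl)phenyl would give a similar step on the longer chain of compound 2, or on a shorter chain, given that compound 2 differs from the other compounds in both its chain and its aryl group.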